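Moving the methyl on the aryl group: compound 3 to compound 4

The source may hold more compounds than are shown below. What is called first, only, known or untested is meant among the compounds shown, and "the series" means these compounds.

The series shares one core; compound 1 `CC1CC/C(=N\Nc2ccccc2F)c2ncc(C(=O)O)c(=O)n21`, compound 2 `CC1CC/C(=N\Nc2ccccc2Cl)c2ncc(C(=O)O)c(=O)n21` and compound 3 `Cc1ccccc1N/N=C1\CCC(C)n2c1ncc(C(=O)O)c2=O` differ only in the group on the amine nitrogen. In a functional assay on the whole organism for inhibition, with Rattus norvegicus as the target (on this read-out higher numbers stand for an effect only at larger amounts of compound and lower numbers for an effect already at smaller amounts), compound 1 gives > 1000 umol/kg, which is a limit of the assay rather than a number. In this assay compound 2 likewise reaches only the limit > 1000 umol/kg. Compound 3 reaches only the limit > 100 umol/kg in this assay. With these limits the steps a step that the two limits leave unreadable from compound 1 to compound 2, a step that the two limits leave unreadable from compound 1 to compound 3 and a step that the two limits leave unreadable from compound 2 to compound 3 have no readable size, as the limit of > 100 umol/kg in this assay, at which 1 of the 3 values shown sits, and the limit of > 1000 umol/kg in this assay, at which 2 of the 3 values shown sit, show. Compound 4 `Cc1ccc(N/N=C2\CCC(C)n3c2ncc(C(=O)O)c3=O)cc1` has not been measured; it differs from compound 3 by 4-methylphenyl in place of 2-methylphenyl on an amine nitrogen. Among the measured compounds shown here, no measured step bears on this change, so neither a direction nor a size beyond the scatter can be read from the three compounds measured. Compound 4 is expected to give 300 umol/kg in this assay, within 100 umol/kg to 3000 umol/kg. The step expected is a step that the limit leaves unreadable from compound 3 to compound 4, most likely reported again only as a limit.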

Compound 4, dose for 50% inhibition: > 1000 umol/kg
Compound 4: no number, only a limit; the forecaster's own chance of this, stated with the estimate: 80%; middle value at least 3.3-fold (0.52 log units) from the limit.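

In this assay compound 4 gives > 1000 umol/kg, which is a limit of the assay and not a number. Among the compounds shown here, no step from compound 1, compound 2 or compound 3 to compound 4 can be read. The compounds shown leave open whether 4-methylphenyl in place of 2-methylphenyl on an amine nitrogen changes the read-out at all.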